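A few compounds are considered here, and "the series" means these few. Any claim that something is new, unique, unknown or untested is made for them only; others in the source may bear on it.

Values in a functional assay on OE19 cells (Homo sapiens) for cytotoxicity, read by MTT assay, with a stated time of 48 h; on this read-out higher numbers stand for weaker inhibition and lower numbers for stronger inhibition:

compound 1 `CC1(C)S[C@@H]2/C(=C\C(=O)c3ccco3)C(=O)N2[C@H]1C(=O)OC(c1ccccc1)c1ccccc1`: 54300 nM
compound 2 `CC1(C)S[C@@H]2C/C(=C\C(=O)c3ccccc3)C(=O)N2[C@H]1C(=O)OC(c1ccccc1)c1ccccc1`: 73300 nM
compound 3 `CC1(C)[C@H](C(=O)OC(c2ccccc2)c2ccccc2)N2C(=O)/C(=C/C(=O)c3ccc([N+](=O)[O-])cc3)[C@H]2[S+]1[O-]`: 92400 nM

All three sit at the weak end of this assay . Compound 1 shows the lowest of the three numbers, but compound 2 and compound 3 both lie within the usual scatter of it, so no order among the three is claimed.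

Compound 4 `CCOC(=O)/C=C1/C(=O)N2[C@@H]1SC(C)(C)[C@@H]2C(=O)OC(c1ccccc1)c1ccccc1` differs from compound 1 by ethoxy in place of furan-2-yl on a carbonyl carbon. For the measured compounds named here, no measured pair shows this change, so no step of this kind is known from the series; the three numbers give no hint of which way it might go.

The step from compound 1 to compound 4 is therefore expected to be a 1.3-fold higher number from compound 1 to compound 4 (0.11 log units; within the scatter), not beyond the scatter, in no set direction. Compound 4 is estimated at 70000 nM, with a range of 30000 nM to 160000 nM.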

Compound 4, half-maximal inhibitory concentration: 11200 nM
For compound 4 the middle estimate is 6.3-fold (0.80 log units) above the measured one; the measured number lies below the stated range.
By their numbers in this assay, from the lowest: compound 4; then compounds 1, 2 and 3 (each within the scatter of the next).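

In this assay, for the compounds shown here, the group on this carbonyl carbon is the first change to give a step beyond the scatter: ethoxy in place of furan-2-yl gives a 4.8-fold lower number from compound 1 to compound 4 (0.69 log units; beyond the scatter). The position therefore responds to substitution, and an aromatic ring is not needed there for activity in this assay. No available data account for the step.

This single pair cannot separate the loss of the furan-2-yl ring from the entry of ethoxy. On these data alone, whether a butoxy chain or a carboxylic acid at this place would keep the number of compound 4 remains open.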